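Swapping ethyl for tert-butyl on a carbonyl carbon

This account rests on a few compounds, and the source may have more. Where it says the series, first, only, none or still open, it means among the compounds named here.

Measured in a physicochemical assay for solubility, read by HPLC, in phosphate buffer, measured as kinetic solubility, at pH 7.4; a lower number here means a less soluble compound, a higher number a more soluble compound
Compound 1 `CCC(=O)c1cc(-c2ccc(Cl)cc2)n(-c2ccc(S(N)(=O)=O)cc2)c1` gives 19500 nM
Compound 2 `CCC(=O)c1cc(-c2ccccc2Cl)n(-c2ccc(S(N)(=O)=O)cc2)c1C` gives 38200 nM
Compound 3 `CCC(=O)c1cc(-c2ccc(S(N)(=O)=O)cc2)n(-c2ccc(Cl)cc2)n1` gives 41900 nM

Compound 3 (41900 nM) lies within the usual scatter of compound 2 (38200 nM). Compound 1 gives 19500 nM, and compound 3 has the higher number of the two by a gap beyond the usual scatter. The next compound to be tested, compound 4 `CC(C)(C)C(=O)c1cc(-c2ccc(S(N)(=O)=O)cc2)n(-c2ccc(Cl)cc2)n1`, differs from compound 3 in one place: it has tert-butyl in place of ethyl on a carbonyl carbon. For the measured compounds named here, no measured pair shows this change, so the expectation rests only on the spread of the three values. In this assay a lower number of moderate size is expected (a 2.8-fold lower number from compound 3 to compound 4 (0.45 log units; beyond the scatter)). For compound 4 the estimated value is 15000 nM (expected range 5000 nM to 38000 nM).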

Compound 4, solubility: 6600 nM
The estimate for compound 4 lay 2.3-fold (0.36 log units) above the measured number; the measured number falls inside the stated range.
By their numbers in this assay, from the lowest: compound 4; then compounds 1, 2 and 3 (each within the scatter of the next, the first and the last beyond it).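

In this assay, tert-butyl in place of ethyl on a carbonyl carbon gives a 6.3-fold lower number from compound 3 to compound 4 (0.80 log units; beyond the scatter) with the rest of the molecule unchanged. This one-place comparison shows that the group at this position can by itself shift the number beyond the usual scatter. No supporting measurement here accounts for the drop. From the compounds shown here alone, whether the same swap gives a similar step on the cores of compound 1 and compound 2 remains open. So does how an amine or a longer straight chain would read at this position.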